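Compound 3: a New Ring on the Triple-Bonded Carbon

The compounds below may be only part of what the source reports. "The series", "measured", "known", "first", "only" and "open" are said of these compounds alone.

Going by the values given here, in an assay on CHO cells for displacement of a labelled ligand from adenosine receptor A1 (Homo sapiens), read by scintillation counting, with a stated time of 60 min, tested at 10 uM (a higher number here means more inhibition at the concentration tested (going by the name of the read-out), a lower number less inhibition), compound 2 `CNC(=O)[C@@]12C[C@@H]1[C@@H](n1cnc3c(NC)nc(C#Cc4cccnn4)nc31)[C@H](O)[C@@H]2O` gives 11%, and its only neighbour, compound 1 `CNC(=O)[C@@]12C[C@@H]1[C@@H](n1cnc3c(NC)nc(C#Cc4cccc(F)c4)nc31)[C@H](O)[C@@H]2O`, gives 14% in this assay; the two sit within the scatter of each other, as the step of a number 3 percentage points lower from compound 1 to compound 2 (within the scatter) shows. Compound 3 `CNC(=O)[C@@]12C[C@@H]1[C@@H](n1cnc3c(NC)nc(C#Cc4cc(C)c(C)o4)nc31)[C@H](O)[C@@H]2O` differs from compound 2 by 4,5-dimethylfuran-2-yl in place of pyridazin-3-yl on a triple-bonded carbon. Among the compounds with values here, the one measured step that bears on this, a number 3 percentage points lower from compound 1 to compound 2 (within the scatter), also swapped the ring on the triple-bonded carbon and was small, so the author expects a number 1 percentage points higher from compound 2 to compound 3 (within the scatter), nothing beyond the scatter. Compound 3 is therefore estimated at 12% in this assay, within a range from 2% to 26%.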

Compound 3, a percentage reported as inhibition, at one concentration (the size of the read-out at that concentration, not a potency): 15%
Beside the measured number, compound 3's estimate is 3 percentage points below it, and the stated range covers the measured number.
By their numbers in this assay, from the lowest: compounds 2, 1 and 3 (each within the scatter of the next).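

In this assay, a five-membered aromatic ring on the triple-bonded carbon reads much like the six-membered rings before it: a number 4 percentage points higher from compound 2 to compound 3 (within the scatter), and a number 1 percentage points higher from compound 1 to compound 3 (within the scatter). Across 3-fluorophenyl, pyridazin-3-yl and 4,5-dimethylfuran-2-yl, this position has therefore shown no step beyond the scatter, even with a change of ring size. No evidence is available that bears on this result.

As far as these compounds go, whether an amine or a carboxylic acid on the ring, or a longer chain in its place, would move the number beyond the scatter stays open. From the compounds shown here alone, all three compounds share one core, so changes elsewhere remain untested by these data.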